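The compounds below may be only part of what the source reports. "The series", "measured", "known", "first", "only" and "open" are said of these compounds alone.

In a functional assay on HCT-116 cells (Homo sapiens) for antiproliferative activity, read by CCK-8 assay, with a stated time of 72 h, tested at 8 uM (a lower number here means a weaker effect, a higher number a stronger effect of the compound at the concentration tested), compound 3 `CCCCn1cnc2c(Nc3ccccc3)nc(NCOCc3ccc(/C=C/C(=O)Nc4ccccc4N)cc3)nc21` stands highest of the three compounds measured, at 51.9%. Its nearest neighbour is compound 1 `CC(C)n1cnc2c(Nc3ccccc3)nc(NCOCc3ccc(/C=C/C(=O)Nc4ccccc4N)cc3)nc21`, at 41.7%, and the step of a number 10.2 percentage points higher from compound 1 to compound 3 (beyond the scatter) lies beyond the scatter. For the measured compounds named here, compound 2 `Nc1ccccc1NC(=O)/C=C/c1ccc(COCNc2nc(Nc3cccc(Cl)c3)c3ncn(C4CCCC4)c3n2)cc1` is the furthest away, at 9.19%; it carries both a cyclopentyl and a chloro group, so no single step connects it to compound 3. Compound 4 `Nc1ccccc1NC(=O)/C=C/c1ccc(COCNc2nc(Nc3ccccc3)c3ncn(C4CCCC4)c3n2)cc1` differs from compound 3 only in one place: cyclopentyl in place of butyl on an aromatic nitrogen. Going by the values given here, the one measured step at this position is a number 10.2 percentage points higher from compound 1 to compound 3 (beyond the scatter), a modest gain; nothing measured isolates cyclopentyl against butyl, and the low value of compound 2 is confounded by its chloro group. A small shift in either direction is therefore expected in this assay for compound 4, a number 6.9 percentage points lower from compound 3 to compound 4 (within the scatter), giving an estimate of 45% with a range from 25% to 62%.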

Compound 4, a percentage reported as inhibition, at one concentration (the size of the read-out at that concentration, not a potency): 17.3%
Compound 4: middle estimate off by 27.7 percentage points, on the high side; measured number below the stated range.
By their numbers in this assay, from the lowest: compounds 2 and 4 (each within the scatter of the next); then compound 1; then compound 3.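

In this assay the group on the aromatic nitrogen matters far more than the earlier step showed: cyclopentyl in place of butyl gives a number 34.6 percentage points lower from compound 3 to compound 4 (beyond the scatter) and cyclopentyl in place of isopropyl gives a number 24.4 percentage points lower from compound 1 to compound 4 (beyond the scatter) on the same core. Hydrogen in place of chloro on an aromatic carbon gives a number 8.1 percentage points higher from compound 2 to compound 4 (within the scatter) and so the chloro group does not account for the low number of compound 2. Nothing available explains the loss with cyclopentyl. As far as these compounds go, whether a longer chain such as hexyl, or a benzyl group, on that nitrogen would match or exceed compound 3 stays open.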